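The source may report more compounds than this note shows. Statements on the series, on what has been measured and on what is new or still open speak of the compounds shown alone.

Measured compounds: compound 1 `COc1cc(/C=C/C(=O)c2cccc(-n3cc(-c4ccccc4)[nH]c3=O)c2)ccc1O` with 2520 nM; compound 3 `COc1ccc(-c2cn(-c3cccc(C(=O)/C=C/c4ccc(O)c(OC)c4)c3)c(=O)[nH]2)cc1` with 3050 nM; compound 2 `O=C(/C=C/c1cccc(O)c1)c1cccc(-n2cc(-c3ccc(Cl)cc3)[nH]c2=O)c1`, for which the result reads "not determined" (no result reported), so no number was reported.

In a functional assay on PC-3 cells (Homo sapiens) for inhibition (on this read-out lower numbers stand for stronger inhibition of growth and higher numbers for weaker inhibition of growth), compound 3 gives 3050 nM, the highest of the two numbers available, but its nearest neighbour, compound 1, sits within the scatter: a 1.2-fold higher number from compound 1 to compound 3 (0.08 log units; within the scatter). So compound 1 and compound 3 cannot be placed in any order on this read-out.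

Compound 4 `COc1cc(/C=C/C(=O)c2cccc(-n3cc(-c4ccc(Cl)cc4)[nH]c3=O)c2)ccc1O` differs from compound 3 in one place: chloro in place of methoxy on an aromatic carbon. Among the compounds with values here, the only measured step, from compound 1 to compound 3, concerns a methoxy entering in place of hydrogen and stayed within the scatter. Within the data shown here, no measured pair shows a chloro entering or a methoxy leaving, so nothing among the measured compounds speaks directly to this change. Compound 2 carries the same chloro-bearing ring as compound 4, but its number in this assay is not available, so it adds nothing.

On this basis he expects no step beyond the scatter in this assay, and the estimated step of a 1.1-fold lower number from compound 3 to compound 4 (0.04 log units; within the scatter) is meant as one of that size. For compound 4 in this assay he therefore estimates 2800 nM, with a range from 1200 nM to 6500 nM.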

Compound 4, concentration for 50% growth inhibition: 1950 nM
The estimate for compound 4 lay 1.4-fold (0.16 log units) above the measured number; the measured number falls inside the stated range.
By their numbers in this assay, from the lowest: compounds 4, 1 and 3 (each within the scatter of the next).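

In this assay the exchange of methoxy for chloro on this aromatic carbon, para to a large group, gives a 1.6-fold lower number from compound 3 to compound 4 (0.19 log units; within the scatter) and so stays inside the scatter, which turns the 4-methoxyphenyl to 4-chlorophenyl change from an open question into a measured one. Chloro in place of hydrogen at the same carbon gives a 1.3-fold lower number from compound 1 to compound 4 (0.11 log units; within the scatter) and also stays inside the scatter, so that with the earlier methoxy step (a 1.2-fold higher number from compound 1 to compound 3 (0.08 log units; within the scatter)) hydrogen, methoxy and chloro here cannot be placed in any order on this read-out, although these three compounds are the only basis for that statement. Nothing available bears on why these three compounds stand so close together.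

On these data alone, whether a group of another kind on this carbon, such as an amine or a carboxylic acid, would carry the number beyond the scatter stays open, since the measured compounds hold only hydrogen, methoxy or chloro there. Steps involving compound 2 cannot be read, as it has no number, so it remains unknown how its different substitution on the hydroxyl-bearing ring would act alongside the chloro group.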